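The compounds below may be only part of what the source reports. "The series", "measured", "known", "first", "only" and "open" are said of these compounds alone.

Compound 1 `CCN/C(SC)=C(/C#N)C(=O)Nc1ccc(OCC)cc1` was examined in an ADME assay on TERT-RPE1 cells (Homo sapiens) for cytotoxicity, read by resazurin assay, with a stated time of 48 h; on this read-out lower numbers stand for stronger inhibition and higher numbers for weaker inhibition. In this assay compound 1 gives > 100000 nM, which is a limit of the assay rather than a number. Compound 2 `C=CCNc1[nH]nc(N)c1C(=O)Nc1ccc(OCC)cc1` gives > 100000 nM in this assay, again a limit. Compound 3 `CCNc1[nH]nc2nnn(-c3ccc(OCC)cc3)c(=O)c12` likewise gives > 100000 nM in this assay, also a limit. Compound 1 thus stands together with the other two at the limit of > 100000 nM in this assay, at which 3 of the 3 values shown sit, and the figures known so far set none of the three apart from the others.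

Compound 4 `CCOc1ccc(NC(=O)/C(C#N)=C(\NC)SC)cc1` differs from compound 1 in a single place: hydrogen in place of methyl on a saturated chain carbon bound to an amine nitrogen. Within the data shown here, no step between measured compounds is on hand to gauge such a change, and the three values known all rest at the limit. The expectation for this assay is a step of no size beyond the usual scatter, with no direction to it. Compound 4 is expected to give 150000 nM, somewhere between 60000 nM and 400000 nM, in this assay. This corresponds to an expected step that the limit leaves unreadable from compound 1 to compound 4, and the assay will most probably once more report only a limit for compound 4.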

Compound 4, half-maximal inhibitory concentration: > 100000 nM
Compound 4 was reported as a limit (the forecaster's own chance of this, stated with the estimate: 85%); the middle value lies beyond the limit too.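

No step can be read between compound 1 and compound 4: in this assay both are reported only as limits, and the change from ethylamino to methylamino has no readable size. The compounds shown leave open what concentration, if any, would produce half-maximal inhibition for any of them, and whether any structural change here shifts the read-out: the limit of > 100000 nM in this assay, at which 4 of the 4 values shown sit.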